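A few compounds are considered here, and "the series" means these few. Any claim that something is new, unique, unknown or untested is made for them only; others in the source may bear on it.

Measured so far in a functional assay on MGC-803 cells (Homo sapiens) for inhibition, read by MTT assay, with a stated time of 72 h; on this read-out higher numbers stand for weaker inhibition and lower numbers for stronger inhibition:
compound 1 `O=C(CSc1nc(Nc2ccccc2)c2ccccc2n1)Nc1ccc(F)c(Cl)c1` gives 20900 nM
compound 2 `C=CC(=O)Nc1cccc(NC(=O)CSc2nc(Nc3ccccc3C)c3ccccc3n2)c1` gives 30200 nM

Compound 2 carries the highest of the two numbers in this assay; compound 1 is its nearest neighbour, and the gap between the two values lies within the scatter, so no order between them can be read. For the measured compounds named here, the two compounds also differ in more than one place, and no single-change step between measured compounds exists in this set.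

Compound 3 `C=CC(=O)Nc1cccc(NC(=O)CSc2nc(Nc3ccc(Cl)cc3Cl)c3ccccc3n2)c1` is not yet measured. It differs from compound 2 in one place: 2,4-dichlorophenyl in place of 2-methylphenyl on a nitrogen on an aromatic ring. Going by the values given here, no measured pair isolates this change, so the size of the step in this assay is unknown; the expectation is for none beyond the scatter, in either direction. For compound 3 the estimated value in this assay is 22000 nM, with a range of 7000 nM to 65000 nM, which corresponds to an expected step of a 1.4-fold lower number from compound 2 to compound 3 (0.14 log units; within the scatter).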

Compound 3, half-maximal inhibitory concentration: 12100 nM
Beside the measured number, compound 3's estimate is 1.8-fold (0.26 log units) above it, and the stated range covers the measured number.
By their numbers in this assay, from the lowest: compounds 3, 1 and 2 (each within the scatter of the next, the first and the last beyond it).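

In this assay, for the compounds shown here, 2,4-dichlorophenyl in place of 2-methylphenyl on a nitrogen on an aromatic ring gives a 2.5-fold lower number from compound 2 to compound 3 (0.40 log units; beyond the scatter) as the first single-change step, modest in size but beyond the scatter. The number therefore responds to the group at this position while the rest of the molecule stays the same, and the change does so with no hydrogen-bond donor, hydrogen-bond acceptor or net charge entering or leaving. No available evidence bears on the reason for this step.

From the compounds shown here alone, the exchange removes the methyl and adds both chlorines at once, so the part each plays remains open. Also open, going by these compounds, is how this position would respond to an unsubstituted phenyl, a pyridyl or a phenyl bearing a carboxylic acid.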